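The source may hold more compounds than are shown below. What is called first, only, known or untested is meant among the compounds shown, and "the series" means these compounds.

Three measured compounds share one core and differ only in the urea aryl ring or at the phenol. In a functional assay on SK-MEL-28 cells (Homo sapiens) for inhibition, read by sulforhodamine B assay, with a stated time of 48 h, tested at 1 uM (on this read-out lower numbers stand for a stronger effect and higher numbers for a weaker effect at the one concentration tested), compound 1 `O=C(Nc1cccc(-n2cc(-c3ccncc3)c(-c3cc(O)cc(Cl)c3)n2)c1)Nc1ccc(Cl)c(C(F)(F)F)c1` gives 81%, compound 2 `O=C(Nc1cccc(-n2cc(-c3ccncc3)c(-c3cc(O)cc(Cl)c3)n2)c1)Nc1ccc(Cl)c(Cl)c1` gives 90%, and compound 3 `COc1cc(Cl)cc(-c2nn(-c3cccc(NC(=O)Nc4ccc(Cl)c(C(F)(F)F)c4)c3)cc2-c2ccncc2)c1` gives 85%. On these numbers compound 3 is the second highest of the three, nearest to compound 1 and furthest from compound 2, both gaps within the scatter. Compound 4 `COc1cc(Cl)cc(-c2nn(-c3cccc(NC(=O)Nc4ccc(Cl)c(Cl)c4)c3)cc2-c2ccncc2)c1` differs from compound 3 in one place: chloro in place of trifluoromethyl on an aromatic carbon. The same change has been made once before, giving a number 9 percentage points higher from compound 1 to compound 2 (within the scatter). The other measured step, a number 4 percentage points higher from compound 1 to compound 3 (within the scatter), concerns a different place and does not bear on it. Compound 4 is therefore expected to show no step beyond the scatter, estimated as a number 6 percentage points higher from compound 3 to compound 4 (within the scatter). For compound 4 the estimate is 91%, with a range from 80% to 100%.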

Compound 4, a percentage reported as activity, at one concentration (the size of the read-out at that concentration, not a potency): 87%
Beside the measured number, compound 4's estimate is 4 percentage points above it; low and high end bracket the measured number.
By their numbers in this assay, from the lowest: compounds 1, 3, 4 and 2 (each within the scatter of the next).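

In this assay, chloro in place of trifluoromethyl now reads on a second core, a number 2 percentage points higher from compound 3 to compound 4 (within the scatter), so the change stays within the scatter with the phenol and with its methyl ether: the same change on two cores in this assay, a number 9 percentage points higher (within the scatter) from compound 1 to compound 2 and a number 2 percentage points higher (within the scatter) from compound 3 to compound 4, 7 percentage points apart, within the scatter of two such steps. Methyl in place of hydrogen on the phenol oxygen also reads on a second urea aryl ring, a number 3 percentage points lower from compound 2 to compound 4 (within the scatter), and again stays within the scatter: the same change on two cores in this assay, a number 4 percentage points higher (within the scatter) from compound 1 to compound 3 and a number 3 percentage points lower (within the scatter) from compound 2 to compound 4, 7 percentage points apart, within the scatter of two such steps. Neither change shows a dependence on the other place at this single concentration.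

On these data alone, whether either place can shift this read-out beyond the scatter stays open. So does the outcome with a nitrile or a carboxylic acid in place of the trifluoromethyl or chloro group.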